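The source may report more compounds than this note shows. Statements on the series, on what has been measured and on what is new or still open speak of the compounds shown alone.

Measured compounds in an ADME assay on HeLa cells (Homo sapiens) for cytotoxicity, read by sulforhodamine B assay, with a stated time of 48 h, tested at 10 uM; on this read-out lower numbers stand for less inhibition and higher numbers for more inhibition at the one concentration tested (going by the name of the read-out):
compound 1 `CCCCCCCc1cn(C(c2ccccc2)c2cc3cc(Br)ccc3nc2OC)nn1` gives 9.7%;
compound 2 `COc1nc2ccc(Br)cc2cc1C(c1ccccc1)n1cc(-c2ccc(OC(F)(F)F)cc2)nn1` gives -2.24%;
compound 3 `COc1nc2ccc(Br)cc2cc1C(c1ccccc1)n1cc(CCCCCO)nn1` gives 1.08%.

Compound 1 carries the highest of the three numbers; compound 3 sits within the scatter of it, while compound 2 lies beyond it. Compound 4 `COc1nc2ccc(Br)cc2cc1C(c1ccccc1)n1cc(-c2ccccc2C(F)(F)F)nn1` has not yet been measured. It differs from compound 1 in one place: 2-(trifluoromethyl)phenyl in place of heptyl on an aromatic carbon. The step that bears on this is a number 11.9 percentage points lower from compound 1 to compound 2 (beyond the scatter), where another aromatic ring took the place of the same heptyl chain. The step of a number 8.6 percentage points lower from compound 1 to compound 3 (within the scatter) touched only the chain end and stayed within the scatter. Compound 4 is therefore expected to come out somewhat lower than compound 1, with an expected step of a number 9.7 percentage points lower from compound 1 to compound 4 (within the scatter). The estimate for compound 4 in this assay is 0%, with a range from -10% to 10%.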

Compound 4, a percentage reported as inhibition, at one concentration (the size of the read-out at that concentration, not a potency): -1.3%
Beside the measured number, compound 4's estimate is 1.3 percentage points above it; the range from low to high includes it.
By their numbers in this assay, from the lowest: compounds 2, 4, 3 and 1 (each within the scatter of the next, the first and the last beyond it).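

In this assay, a second aromatic ring in place of heptyl on this carbon of the five-membered ring again lands beyond the scatter, with a number 11 percentage points lower from compound 1 to compound 4 (beyond the scatter) here, so the earlier shift with compound 2 is not unique to one aromatic group. The readings a number 0.9 percentage points higher from compound 2 to compound 4 (within the scatter) and a number 2.4 percentage points lower from compound 3 to compound 4 (within the scatter) both stay within the scatter, so these three replacements for heptyl cannot be told apart here. Nothing available explains the result. On these data alone, whether an amine, a carboxylic acid or a chain longer than heptyl at this position would match or exceed compound 1 stays open.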